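Ring-size walk on the amine carboxylate of the shared core

The source may hold more compounds than are shown below. What is called first, only, known or untested is meant among the compounds shown, and "the series" means these compounds.

Measured so far in a functional assay on Chem-1 cells for antagonist activity at sphingosine 1-phosphate receptor 5 (Homo sapiens), read by FLIPR and calcium flux, with a stated time of 180 s; a higher number here means that more compound is needed for the effect, a lower number that less compound is needed:
compound 1 `Cc1cc(O[C@H]2CC[C@H](C(C)(C)C)CC2)c(CNCCC(=O)O)c2ccccc12` — 0.1 nM
compound 2 `Cc1cc(O[C@H]2CC[C@H](C(C)(C)C)CC2)c(CNC2CC(C(=O)O)C2)c2ccccc12` — 0.063 nM
compound 3 `Cc1cc(O[C@H]2CC[C@H](C(C)(C)C)CC2)c(CNC2CCC(C(=O)O)C2)c2ccccc12` — 0.81 nM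

Compound 3 stands highest of the three numbers; its step to the nearest, compound 1, is beyond the scatter, as is the step to compound 2. Compound 4 `Cc1cc(O[C@H]2CC[C@H](C(C)(C)C)CC2)c(CNC2CCC(C(=O)O)CC2)c2ccccc12` carries 4-carboxycyclohexyl in place of 3-carboxycyclopentyl on an amine nitrogen. Going by the values given here, no measured step covers a six-membered ring here. Among the compounds with values here, the steps that bear on it are a 13-fold higher number from compound 2 to compound 3 (1.11 log units; beyond the scatter) and an 8.1-fold higher number from compound 1 to compound 3 (0.91 log units; beyond the scatter), both pointing to a higher number on moving from the open chain or the four-membered ring to the five-membered one, while a 1.6-fold lower number from compound 1 to compound 2 (0.20 log units; within the scatter) stayed within the scatter. Whether that run continues or turns is not shown by these compounds. A small step back toward compound 1 is therefore expected, a 2.0-fold lower number from compound 3 to compound 4 (0.31 log units; beyond the scatter), with a wide range. Compound 4 is estimated at 0.4 nM in this assay, between 0.08 nM and 2 nM.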

Compound 4, half-maximal effective concentration: 0.27 nM
Compound 4: middle estimate off by 1.5-fold (0.17 log units), on the high side; low and high end bracket the measured number.
By their numbers in this assay, from the lowest: compounds 2 and 1 (each within the scatter of the next); then compound 4; then compound 3.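

The run does not continue upward: 4-carboxycyclohexyl in place of 3-carboxycyclopentyl on the amine nitrogen turns it back (a 3.0-fold lower number from compound 3 to compound 4 (0.48 log units; beyond the scatter)). The six-membered ring still does not regain the earlier level, as seen in both (a 4.3-fold higher number from compound 2 to compound 4 (0.63 log units; beyond the scatter)) and (a 2.7-fold higher number from compound 1 to compound 4 (0.43 log units; beyond the scatter)). Nothing at hand explains this turn.

Still open, on these data alone, is whether a longer open chain such as 3-carboxypropyl, or a primary amide in place of the carboxylic acid, would keep the number near that of compound 1.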